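This account rests on a few compounds, and the source may have more. Where it says the series, first, only, none or still open, it means among the compounds named here.

Of the compounds shown here, three sharing one core have been measured in a functional assay on PC-9 cells (Homo sapiens) for inhibition, read by MTT assay, with a stated time of 48 h, tested at 10 uM; a higher number here means more inhibition at the concentration tested (going by the name of the read-out), a lower number less inhibition. Compound 1 `COc1cc(NC(=O)Nc2cc(Nc3cc(Br)ccc3OC)ncn2)cc(OC)c1` gives 82.5%. Compound 2 `COc1cc(NC(=O)Nc2cc(Nc3cccc(C(C)(C)C)c3)ncn2)cc(OC)c1` gives 68%. Compound 3 `COc1cc(NC(=O)Nc2cc(Nc3ccc(OC)c(I)c3)ncn2)cc(OC)c1` gives 47.1%, the lowest of the three numbers, and the steps from both other compounds to it lie beyond the scatter.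

The next compound, compound 4 `COc1cc(NC(=O)Nc2cc(Nc3ccc(F)c(Cl)c3)ncn2)cc(OC)c1`, differs from compound 3 only at the aromatic ring attached to the nitrogen: 3-chloro-4-fluorophenyl in place of 3-iodo-4-methoxyphenyl on a nitrogen on an aromatic ring

Every step measured so far changes that same ring, so all three bear on this one. The step of a number 35.4 percentage points lower from compound 1 to compound 3 (beyond the scatter) was large, and the steps of a number 14.5 percentage points lower from compound 1 to compound 2 (beyond the scatter) and a number 20.9 percentage points lower from compound 2 to compound 3 (beyond the scatter) were modest. This group therefore moves the read-out strongly, but nothing in the data says which way a 3-chloro-4-fluorophenyl will move it. Since compound 3 sits at the bottom of the range, and compound 2, which also lacks a methoxy group on this ring, gives a higher number, a modest rise is the expectation, with wide uncertainty. Compound 4 is expected to give about 60%, between 35% and 85%, so the estimated step is a number 12.9 percentage points higher from compound 3 to compound 4 (beyond the scatter).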

Compound 4, a percentage reported as inhibition, at one concentration (the size of the read-out at that concentration, not a potency): 77.5%
Beside the measured number, compound 4's estimate is 17.5 percentage points below it, and the stated range covers the measured number.
By their numbers in this assay, from the lowest: compound 3; then compounds 2, 4 and 1 (each within the scatter of the next, the first and the last beyond it).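

In this assay, replacing the 3-iodo-4-methoxyphenyl group with 3-chloro-4-fluorophenyl gives a number 30.4 percentage points higher from compound 3 to compound 4 (beyond the scatter), which shows that a change confined to this one ring can shift the read-out by a large amount. The new group also gives a number 5 percentage points lower from compound 1 to compound 4 (within the scatter) and a number 9.5 percentage points higher from compound 2 to compound 4 (within the scatter), so three differently substituted rings cannot be separated here, and neither a methoxy group nor a halogen sorts the compounds on its own: compound 1 and compound 3 both carry both kinds of group, yet they lie far apart, while compound 4 has no methoxy group and compound 2 has no halogen. No measurement shown accounts for why compound 3 stands apart from the others.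

Since the step from compound 3 to compound 4 alters two groups on the ring at once, the compounds shown cannot say whether the swap of iodine for chlorine or that of methoxy for fluorine carries the change. On these data alone, it also remains open how a ring bearing an amine or a carboxylic acid would behave at this position.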